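This account rests on a few compounds, and the source may have more. Where it says the series, first, only, none or still open, it means among the compounds named here.

Of the compounds shown here, three that share one core have been tested in a functional assay on CHO cells for positive allosteric modulation of muscarinic acetylcholine receptor M5 (Homo sapiens), read by FLIPR and calcium flux, with a stated time of 1 h; a lower number here means a smaller maximal response, a higher number a larger maximal response. Compound 1 `O=C1C(=O)N(Cc2ccc(Cl)nc2)c2ccc(OC(F)(F)F)cc21` carries a relatively small group on the part of the core that varies across the set; in this assay compound 1 gives 80%. Compound 2 `O=C1C(=O)N(Cc2ccc(-c3ccccc3)cn2)c2ccc(OC(F)(F)F)cc21` carries a larger, more extended group in the same region, and in this assay compound 2 gives 47%. Compound 3 `COc1cccc(Oc2ccc(CN3C(=O)C(=O)c4cc(OC(F)(F)F)ccc43)cc2)n1` also carries a large, extended group there, and in this assay compound 3 gives 51%. Among these three numbers compound 3 stands second highest: its value sits close to that of compound 2, a gap within the usual scatter of the measurement, while it lies well under compound 1 by a gap that is beyond the scatter.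

Compound 4 `O=C1C(=O)N(Cc2ccc(-c3ccncc3)cc2)c2ccc(OC(F)(F)F)cc21` has not yet been measured. It differs from compound 3 in one place: pyridin-4-yl in place of (6-methoxypyridin-2-yl)oxy on an aromatic carbon. The group that enters is smaller than the one that leaves, but compound 4 still carries an extended group in the same region, as compound 2 and compound 3 do. For compound 4 the expected step is a number 1 percentage points lower from compound 3 to compound 4 (within the scatter), a change judged to stay within the usual scatter. Compound 4 is therefore estimated at 50%, with a range from 30% to 72%.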

Compound 4, largest response reached (Emax), in percent of the reference or control that the assay uses: 60%
Beside the measured number, compound 4's estimate is 10 percentage points below it; measured number inside the range.
By their numbers in this assay, from the lowest: compounds 2, 3 and 4 (each within the scatter of the next, the first and the last beyond it); then compound 1.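

In this assay, putting pyridin-4-yl in place of (6-methoxypyridin-2-yl)oxy, on an aromatic carbon para to a large group, gives a number 9 percentage points higher from compound 3 to compound 4 (within the scatter). Among these compounds, this is the first comparison in the set in which only one place differs, and it shows that the maximal response cannot be told apart across this exchange, even though the oxygen link and the methoxy group both leave and the entering group has fewer heavy atoms and fewer hydrogen-bond acceptors. Both groups contain a six-membered aromatic ring with one hetero atom, but no measurement here explains why the two compounds cannot be separated.

The compounds shown leave open whether a different kind of group on this aromatic carbon, such as an amine, a carboxylic acid or a longer chain, would keep the response in the same range. They also leave open what the oxygen link and the methoxy group each contribute on their own, as both change together in this single exchange.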